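A few compounds are considered here, and "the series" means these few. Any claim that something is new, unique, unknown or untested is made for them only; others in the source may bear on it.

Compound 1 `O=C1CC(c2ccc(Br)cc2)Nc2c(Br)cc(Br)cc21` is a small molecule built on a shared core that carries two bromo groups, with a bromo-substituted phenyl ring attached to it. Among the measured compounds shown here, in a functional assay on MCF7 cells (Homo sapiens) for inhibition, read by sulforhodamine B assay, with a stated time of 48 h (a lower number here means a stronger inhibitor of growth, a higher number a weaker inhibitor of growth), compound 1 gives 151 nM, and it is the only compound of the set with a number in this assay. Compound 2 `O=C1CC(c2cccc(O)c2)Nc2c(Br)cc(Br)cc21` replaces that bromo-substituted phenyl ring with a hydroxy-substituted one. In this assay compound 2 gives > 100000 nM, which is a limit of the assay and not a number. This value of compound 2 sits at the limit of > 100000 nM in this assay, at which 1 of the 2 values shown sits. Compound 3 `CN(C)c1ccc(C2CC(=O)c3cc(Br)cc(Br)c3N2)cc1` has not yet been measured in this assay. It differs from compound 1 in one place: dimethylamino in place of bromo on an aromatic carbon. For the measured compounds named here, no step between measured compounds that differ in one place is available to guide the size of this change. The step from compound 1 to compound 3 is expected to be a 2.0-fold higher number from compound 1 to compound 3 (0.30 log units; within the scatter), within the scatter or a little weaker. For compound 3 a value of 300 nM is estimated, with a range from 30 nM to 5000 nM.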

Compound 3, concentration for 50% growth inhibition: > 100000 nM
Compound 3: no number, only a limit (the forecaster's own chance of this, stated with the estimate: 15%); middle value at least 330-fold (2.52 log units) from the limit.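

In this assay, putting dimethylamino in place of bromo on this aromatic carbon, para to a large group, gives an at least 660-fold higher number from compound 1 to compound 3 (2.82 log units; beyond the scatter). This position is therefore sensitive to what it carries: a single change here, with the rest of the molecule untouched, is enough to take a compound with a measurable effect on growth to the edge of what the assay can report. From the compounds shown here alone, compound 3 gives > 100000 nM, which is a limit of the assay and not a number, so its true value remains unknown: the limit of > 100000 nM in this assay, at which 2 of the 3 values shown sit.

Why dimethylamino has this effect cannot be told from these compounds. Going by these compounds, it also remains open whether a chloro or methyl group on the same carbon would keep the activity of compound 1, and whether a plain amine would behave like dimethylamino.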